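Oxime ether in place of amidoxime on a shared thioether

The source may report more compounds than this note shows. Statements on the series, on what has been measured and on what is new or still open speak of the compounds shown alone.

Notes on a thioether-linked pair measured in a functional assay (blood) for inhibition, with Homo sapiens as the target; a lower number here means a stronger inhibitor, a higher number a weaker inhibitor. Compound 1 `CN(C)/C(=N\O)c1ccc(Sc2cc(F)cc(C3CCOCC3)c2)cc1` gives 280 nM in this assay, the lowest of the two numbers recorded so far. Compound 2 `CO[C@]1(c2cnc(S(=O)(=O)c3ccc(/C(C)=N/O)cc3)s2)CCO[C@@H](C)C1` gives 320 nM in this assay; the gap between compound 1 and compound 2 lies within the usual scatter, so the two cannot be placed in order. Compound 3 `C/C(=N\OC(C)C)c1ccc(Sc2cc(F)cc(C3CCOCC3)c2)cc1` has not been measured yet. It differs from compound 1 in one place: a group of 7 heavy atoms (5 carbon, 1 nitrogen, 1 oxygen; no ring) in place of a group of 6 heavy atoms (3 carbon, 2 nitrogen, 1 oxygen; no ring), on an aromatic carbon. The group that leaves has a hydrogen-bond donor, the group that enters has none, and both sit on the aromatic carbon para to a large group. Within the data shown here, no measured pair makes a change of this kind, so the size of the step has no precedent here. For compound 3 a step within the scatter or a modest loss is expected, a 1.4-fold higher number from compound 1 to compound 3 (0.15 log units; within the scatter) being the working guess. Compound 3 is estimated at 400 nM in this assay, within a range from 120 nM to 1300 nM.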

Compound 3, half-maximal inhibitory concentration: 920 nM
The estimate for compound 3 lay 2.3-fold (0.36 log units) below the measured number; measured number inside the range.
By their numbers in this assay, from the lowest: compounds 1 and 2 (each within the scatter of the next); then compound 3.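

In this assay, among these compounds, the aromatic carbon para to a large group proves sensitive to this exchange, with a step of a 3.3-fold higher number from compound 1 to compound 3 (0.52 log units; beyond the scatter), the only step that can be read at this place. The exchange removes the hydrogen-bond donor, keeps the count of hydrogen-bond acceptors and adds one heavy atom, and the cost of this combined change is a modest loss rather than a complete one. Nothing measured on these compounds bears on what lies behind the higher number.

Because the donor count, the heavy-atom count and the atom composition all change in one step, the compounds shown cannot assign the loss to any one of these differences. On these data alone, it remains open whether an amine or a carboxylic acid on this aromatic carbon, or a longer chain on the oxime oxygen of the entering group, would bring the number back towards that of compound 1 at 280 nM or move it further away.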